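Predicting a Methylated Analogue in a Cell Cytotoxicity Assay

The source may report more compounds than this note shows. Statements on the series, on what has been measured and on what is new or still open speak of the compounds shown alone.

Three compounds sharing one core were tested in a functional assay on HT-29 cells (Homo sapiens) for cytotoxicity, read by MTT assay, with a stated time of 24 h; on this read-out lower numbers stand for stronger inhibition and higher numbers for weaker inhibition. Compound 1 `c1ccc(CNC(c2ccc[nH]2)c2nnc(-c3ccccc3)o2)cc1` gives 198000 nM. Compound 2 `Brc1ccc(-c2nnc(C(NCc3ccccc3)c3ccc[nH]3)o2)cc1` differs from compound 1 by bromo in place of hydrogen on an aromatic carbon, and compound 2 gives 58300 nM; this is the lowest number of the three, and the step of a 3.4-fold lower number from compound 1 to compound 2 (0.53 log units; beyond the scatter) lies beyond the scatter. Compound 3 `Cc1cccc(-c2nnc(C(NCc3ccccc3)c3ccc[nH]3)o2)c1` differs from compound 1 by methyl in place of hydrogen on an aromatic carbon, and compound 3 gives 202000 nM; the step of a 1.0-fold higher number from compound 1 to compound 3 (0.01 log units; within the scatter) lies within the scatter, so the two cannot be told apart. Comparing compound 2 and compound 3 directly, the step of a 3.5-fold higher number from compound 2 to compound 3 (0.54 log units; beyond the scatter) is beyond the scatter.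

Compound 4 `Cc1ccc(CNC(c2ccc[nH]2)c2nnc(-c3ccc(Br)cc3)o2)cc1` has not yet been measured in this assay. It differs from compound 2 by methyl in place of hydrogen on an aromatic carbon. For the measured compounds named here, this is the same kind of change as the one from compound 1 to compound 3, but not the same: there the methyl entered meta to a large group, on the phenyl that becomes 3-methylphenyl, whereas here it enters para to a large group, on the benzyl that becomes 4-methylbenzyl. The core on which the new change is made differs from that of compound 1 by bromo in place of hydrogen on an aromatic carbon.

Going by the values given here, with only one earlier example, the expectation for compound 4 is that the step of a 1.0-fold higher number from compound 2 to compound 4 (0.01 log units; within the scatter) stays within the scatter, resting on the step of a 1.0-fold higher number from compound 1 to compound 3 (0.01 log units; within the scatter) seen for compound 3. The estimate for compound 4 is therefore 60000 nM, between 25000 nM and 150000 nM.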

Compound 4, half-maximal inhibitory concentration: 49500 nM
Compound 4: middle estimate off by 1.2-fold (0.08 log units), on the high side; the measured number falls inside the stated range.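

In this assay, putting a methyl on the benzyl of compound 2 gives a 1.2-fold lower number from compound 2 to compound 4 (0.07 log units; within the scatter), so compound 4 and compound 2 cannot be told apart. Set beside the earlier methyl step, this suggests that in these two pairs the bromo on the core does not alter what a methyl does to the number, as neither step moves it beyond the scatter and the two steps agree: the same change on two cores in this assay, a 1.0-fold higher number (0.01 log units; within the scatter) from compound 1 to compound 3 and a 1.2-fold lower number (0.07 log units; within the scatter) from compound 2 to compound 4, 1.2-fold (0.08 log units) apart, within the scatter of two such steps. This does not show that a methyl can be carried freely from core to core in this series: the result rests on just two pairs, and the methyl sits on a different ring in each, as 3-methylphenyl in compound 3 and as 4-methylbenzyl in compound 4, so the effect of the core cannot be separated from the effect of the methyl's place.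

The compounds shown leave open what a 4-methylbenzyl would do on the core of compound 1, and what a 3-methylphenyl would do on the core of compound 2. They also leave open whether a different group on the benzyl, such as an amine, a carboxylic acid or a longer chain like propyl, would stay as close to compound 2 as the methyl does.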